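Lengthening an Amide Chain in Melatonin Receptor Binders

The source may report more compounds than this note shows. Statements on the series, on what has been measured and on what is new or still open speak of the compounds shown alone.

Of the compounds shown here, three have been measured in an assay for binding affinity to melatonin receptor (Gallus gallus); a higher number here means a weaker inhibitor, a lower number a stronger inhibitor. Compound 1, with the structure `COc1cccc(CNC(C)=O)c1`, gives 57000 nM in this assay. Compound 2, with the structure `CCC(=O)NCc1cccc(OC)c1`, gives 22000 nM in this assay. Compound 3, with the structure `CCCC(=O)NCCCCc1ccc(OC)cc1`, gives 822 nM in this assay, the lowest number of the three, and its distance to each of the other two lies beyond the usual scatter.

Compound 1 and compound 2 share a core and differ in one place: methyl in place of hydrogen on a saturated chain carbon bound to a carbonyl carbon. That change produced a 2.6-fold lower number from compound 1 to compound 2 (0.41 log units; beyond the scatter), a modest but real step.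

Compound 4, with the structure `CCCCC(=O)NCCCCc1ccc(OC)cc1`, has not yet been measured. It differs from compound 3 in one place: methyl in place of hydrogen on a saturated chain carbon, three bonds along the chain from a carbonyl carbon. Within the data shown here, this is the same kind of change as the one between compound 1 and compound 2, but the place is not the same: there the methyl entered on a saturated chain carbon bound to a carbonyl carbon, here it enters on a saturated chain carbon three bonds along the chain from a carbonyl carbon. The cores of compound 1 and compound 3 also differ, and that difference is not broken down here.

Among the measured compounds shown here, for compound 4 in this assay a step of a 1.4-fold lower number from compound 3 to compound 4 (0.14 log units; within the scatter) is expected, somewhat smaller than the earlier one, because the one comparable step measured, a 2.6-fold lower number from compound 1 to compound 2 (0.41 log units; beyond the scatter), was made at a different place on a different core and so only loosely guides this case. Compound 4 is therefore estimated at 600 nM in this assay, with a likely range from 250 nM to 1500 nM.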

Compound 4, inhibition constant: 7000 nM
Estimate against measurement, compound 4: 12-fold (1.07 log units) below; the whole stated range lies below it.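

Adding one methyl to the amide chain did not repeat its earlier result: in this assay the change gave an 8.5-fold higher number from compound 3 to compound 4 (0.93 log units; beyond the scatter) and so made compound 4 a weaker binder, whereas the earlier methyl step had gone the other way. Set side by side, the two steps point in opposite directions, and the gap between them is larger than the usual scatter of repeated measurements allows: the same change on two cores in this assay, a 2.6-fold lower number (0.41 log units; beyond the scatter) from compound 1 to compound 2 and an 8.5-fold higher number (0.93 log units; beyond the scatter) from compound 3 to compound 4, 22-fold (1.34 log units) apart, beyond the scatter of two such steps. This shows that a gain from adding a methyl on the core of compound 1 cannot simply be assumed on the core of compound 3, but it does not show why, since the two steps differ both in the core and in the place of the methyl, and one step on each core cannot separate these two differences.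

The compounds shown leave open whether a methyl on a saturated chain carbon bound to a carbonyl carbon would give a lower or a higher number on the core of compound 3. They also leave open how a longer chain, or a cyclopropyl group at the same place as the new methyl, would behave on that core.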